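Furan-3-yl for cyclopentyl in a dihydropyrimidine series

This account rests on a few compounds, and the source may have more. Where it says the series, first, only, none or still open, it means among the compounds named here.

Measured compounds:
compound 1, `CCOC(=O)C1=C(C)N/C(=N\C#N)NC1c1ccco1`, 20% in an assay on HeLa cells for displacement of a labelled ligand from adenosine receptor A3 (Homo sapiens), with a stated time of 180 min, tested at 1 uM; a lower number here means less inhibition, a higher number more inhibition at the concentration tested (going by the name of the read-out)
compound 2, `CCOC(=O)C1=C(C)N/C(=N\C#N)NC1C1CCCC1`, 4%

In this assay compound 2 gives the lowest of the two numbers; its nearest neighbour is compound 1, and a number 16 percentage points lower from compound 1 to compound 2 (beyond the scatter). Compound 3, `CCOC(=O)C1=C(C)N/C(=N\C#N)NC1c1ccoc1`, has not been measured. It differs from compound 2 in one place: furan-3-yl in place of cyclopentyl on a saturated ring carbon. The furan-3-yl that enters is, like the furan-2-yl of compound 1, a five-membered aromatic ring with one hetero atom and one hydrogen-bond acceptor, whereas the cyclopentyl that leaves has neither. Among the compounds with values here, the only step that bears on the change is the one from compound 1 to compound 2, where the reverse exchange lowered the number by a modest amount beyond the scatter. Compound 3 is therefore expected to sit closer to compound 1 than to compound 2, with a step of a number 11 percentage points higher from compound 2 to compound 3 (beyond the scatter) upward. The estimate for compound 3 in this assay is 15%, with a range from 0% to 32%.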

Compound 3, a percentage reported as inhibition, at one concentration (the size of the read-out at that concentration, not a potency): 14%
Estimate against measurement, compound 3: 1 percentage points above, within the range that was stated.
By their numbers in this assay, from the lowest: compounds 2, 3 and 1 (each within the scatter of the next, the first and the last beyond it).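

In this assay, on the saturated ring carbon, furan-3-yl in place of cyclopentyl gives a number 10 percentage points higher from compound 2 to compound 3 (within the scatter), so this exchange alone cannot be told apart from repeat measurements, even though the step with the other furan, a number 16 percentage points lower from compound 1 to compound 2 (beyond the scatter), is beyond the scatter. Furan-3-yl in place of furan-2-yl gives a number 6 percentage points lower from compound 1 to compound 3 (within the scatter), so the point at which the furan is attached makes no difference that this read-out can resolve, and compound 3 lies within the scatter of both neighbours without separating them. Nothing at hand explains any of these numbers.

The compounds shown leave open whether a phenyl ring, an aminomethyl group or a longer alkyl chain on this saturated ring carbon would give a number beyond the scatter of all three compounds. They also leave open whether compound 1 and compound 3 would stay within the scatter of each other at a concentration other than the one tested.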